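Ethoxy to chloro in the series: notes on compound 3

The compounds below may be only part of what the source reports. "The series", "measured", "known", "first", "only" and "open" are said of these compounds alone.

Of the compounds shown here, two sharing one core have numbers so far in a physicochemical assay for lipophilicity, read by mass spectrometry; a higher number here means a more lipophilic compound, a lower number a more polar compound. Compound 1 `COc1ccc(NC(=O)C2Cc3cc(OC)c(OC)cc3C2=O)cc1` gives 2.08, and compound 2 `CCOc1ccc(NC(=O)C2Cc3cc(OC)c(OC)cc3C2=O)cc1` gives 2.42, the higher of the two numbers.

Next in line is compound 3 `COc1cc2c(cc1OC)C(=O)C(C(=O)Nc1ccc(Cl)cc1)C2`, which differs from compound 2 by chloro in place of ethoxy on an aromatic carbon, para to a large group (chloro in place of ethoxy on an aromatic carbon).

For the measured compounds named here, only one measured step bears on this change, and only indirectly: a number 0.34 log units higher from compound 1 to compound 2 (beyond the scatter), a modest step beyond the scatter that alters the group now leaving. Going by the values given here, no measured compound carries chloro, so neither the size nor the direction of the new step is directly covered by the data. Among the compounds with values here, with that single step as the only guide to size, a modest rise in this assay is expected, and the range is kept wide enough to reach back close to compound 2. The expected change is estimated as a number 0.28 log units higher from compound 2 to compound 3 (within the scatter). Compound 3 is estimated at 2.7, with an expected range from 2.3 to 3.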

Compound 3, partition coefficient: 2.76
For compound 3 the middle estimate is 0.06 log units below the measured one, and the stated range covers the measured number.
By their numbers in this assay, from the lowest: compound 1; then compound 2; then compound 3.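

In this assay, replacing ethoxy with chloro on this aromatic carbon, para to a large group, gives a number 0.34 log units higher from compound 2 to compound 3 (beyond the scatter), so the number at this position moves with a change of the group itself, not only with a change of the chain on the oxygen. The size of the entering group does not set the order in these compounds: chloro, with 1 heavy atom and 0 hydrogen-bond acceptors, replaces ethoxy, with 3 heavy atoms and 1 hydrogen-bond acceptor, and compound 3 still stands highest, which goes against any reading of a larger group giving a higher number, even though the methoxy-to-ethoxy step alone might suggest one. Measured directly against methoxy, chloro gives a number 0.68 log units higher from compound 1 to compound 3 (beyond the scatter), but nothing in the data accounts for either new step.

Going by these compounds, whether an amine, a carboxylic acid, a longer alkoxy chain or a bromo group at this position would fall within this order remains open. Also open, on these data alone, is whether these steps carry over to compounds in which the shared core is altered, for instance at the amide hydrogen or the carbonyl.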